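This account rests on a few compounds, and the source may have more. Where it says the series, first, only, none or still open, it means among the compounds named here.

Measured compounds:
Compound 1 `Cc1nc(-c2cccc(NC(=O)C3CCCN(C(=O)c4cc(C(F)(F)F)cc(C(F)(F)F)c4)C3)c2)cs1` gives 1%
Compound 2 `O=C(Nc1ccc(Cl)cc1)C1CCCN(C(=O)c2cccc([N+](=O)[O-])c2)C1` gives 0%
Compound 3 `CC(=O)Nc1cccc(C(=O)N2CCCC(C(=O)Nc3ccc(Cl)cc3)C2)c1` gives 4%

All three numbers come from an ADME assay on PC-3 cells (Homo sapiens) for cytotoxicity, read by WST assay, tested at 100 uM; a lower number here means less inhibition, a higher number more inhibition at the concentration tested (going by the name of the read-out). Compound 1 stands in the middle of the three, but its nearest neighbour is compound 2, one point lower, and its furthest is compound 3, three points higher, and both gaps lie within the usual scatter, so none of the three can be told apart from the others. Every compound here shows essentially no effect on the cells at the concentration tested.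

The step to compound 4 `COc1cccc(NC(=O)C2CCCN(C(=O)c3cc(C(F)(F)F)cc(C(F)(F)F)c3)C2)c1` is a change at the aryl amide end of the shared core: methoxy in place of 2-methyl-1,3-thiazol-4-yl on an aromatic carbon. Within the data shown here, only one measured step is available, and it concerns the other end of the molecule: a number 4 percentage points higher from compound 2 to compound 3 (within the scatter), a step within the scatter. It does not touch the place changed here, so it bears only loosely on the new step; what it does show is that a swap of one aromatic substituent left the read-out flat.

Among the measured compounds shown here, with every measured number near zero and the one measured step flat, the expectation for compound 4 is a step of a number 1 percentage points higher from compound 1 to compound 4 (within the scatter), none beyond the scatter. Compound 4 is therefore estimated at 2%, with a range from -6% to 10%.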

Compound 4, a percentage reported as inhibition, at one concentration (the size of the read-out at that concentration, not a potency): 0%
Compound 4: the middle estimate sits 2 percentage points above what was measured; the measured number falls inside the stated range.
By their numbers in this assay, from the lowest: compounds 2, 4, 1 and 3 (each within the scatter of the next).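

Among these compounds, replacing 3-(2-methyl-1,3-thiazol-4-yl)phenyl with 3-methoxyphenyl gives the first measured change at this position, and in this assay it produces a number 1 percentage points lower from compound 1 to compound 4 (within the scatter) with no departure from the near-zero numbers seen so far. The earlier step concerned the other end of the molecule, whereas this one shows that, for this pair, the read-out does not separate a substituent with a five-membered aromatic ring and 6 heavy atoms from one with no ring and 2 heavy atoms, placed on an aromatic carbon meta to a large group. Nothing measured here explains why the two compounds cannot be told apart.

From the compounds shown here alone, whether a basic amine, a carboxylic acid or a longer alkyl chain at this same place would lift the inhibition beyond the scatter remains open. Among the compounds shown here, because compound 1 and compound 4 form the only pair compared at this position, it is also open whether the same flat result would hold with a different group at the other end of the molecule.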